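Compound 4: 2-phenylethenyl replacing 4-(dimethylamino)phenyl

The compounds below may be only part of what the source reports. "The series", "measured", "known", "first", "only" and "open" are said of these compounds alone.

Compound 1 `Cc1c(O)ccc2cc(-n3cc(-c4ccccc4)nn3)c(=O)oc12` gives 25200 nM in a functional assay on MCF7 cells (Homo sapiens) for antiproliferative activity; on this read-out lower numbers stand for stronger inhibition and higher numbers for weaker inhibition. Compound 2 `Cc1c(O)ccc2cc(-n3cc(-c4ccc(F)cc4F)nn3)c(=O)oc12` gives 33500 nM in this assay, a step of a 1.3-fold higher number from compound 1 to compound 2 (0.12 log units; within the scatter). Compound 3 `Cc1c(O)ccc2cc(-n3cc(-c4ccc(N(C)C)cc4)nn3)c(=O)oc12` reaches only a limit in this assay, > 100000 nM. Compound 3 thus sits at the limit of > 100000 nM in this assay, at which 1 of the 3 values shown sits, and is the weakest of the three, reached through steps of an at least 3.9-fold higher number from compound 1 to compound 3 (0.59 log units; beyond the scatter) and an at least 2.9-fold higher number from compound 2 to compound 3 (0.47 log units; beyond the scatter).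

Compound 4 `Cc1c(O)ccc2cc(-n3cc(/C=C/c4ccccc4)nn3)c(=O)oc12` differs from compound 3 by 2-phenylethenyl in place of 4-(dimethylamino)phenyl on an aromatic carbon. For the measured compounds named here, no measured step carries this exact change; the closest reference is compound 1, which carries a plain phenyl in that place and gives 25200 nM. Since both steps into compound 3 rose beyond the scatter, moving back to a phenyl-bearing group is expected to give an at least 3.3-fold lower number from compound 3 to compound 4 (0.52 log units; beyond the scatter) in this assay. Compound 4 is therefore estimated at 30000 nM, within 12000 nM to 80000 nM.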

Compound 4, half-maximal inhibitory concentration: 33700 nM
The estimate for compound 4 lay 1.1-fold (0.05 log units) below the measured number, and the stated range covers the measured number.
By their numbers in this assay, from the lowest: compounds 1, 2 and 4 (each within the scatter of the next). At a limit, above all of these: compound 3.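

At this aromatic carbon of the five-membered ring, 2-phenylethenyl reads level with phenyl (a 1.3-fold higher number from compound 1 to compound 4 (0.13 log units; within the scatter)) and with 2,4-difluorophenyl (a 1.0-fold higher number from compound 2 to compound 4 (0.00 log units; within the scatter)) in this assay, so one double bond outside aromatic rings brings no step beyond the scatter. Among these groups, only 4-(dimethylamino)phenyl stands apart (an at least 2.9-fold lower number from compound 3 to compound 4 (0.47 log units; beyond the scatter)). Compound 3 stays a limit, not a number: the limit of > 100000 nM in this assay, at which 1 of the 4 values shown sits.

Still open, on these data alone, is how a 4-aminophenyl or 4-methoxyphenyl group would read at this place. Also open, as far as these compounds go, is whether an aliphatic chain or a carboxylic acid could replace the aromatic ring.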